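A few compounds are considered here, and "the series" means these few. Any claim that something is new, unique, unknown or untested is made for them only; others in the source may bear on it.

Of the compounds shown here, three have been measured and one remains. Compound 1 `Cc1ccc(NC(=S)OCCNC(=O)C(C)(C)Oc2ccc(Cl)cc2)cc1` gives 771000 nM in an ADME assay on H9c2 cells (Rattus norvegicus) for cytotoxicity, read by MTT assay, with a stated time of 48 h; a higher number here means a weaker inhibitor, a lower number a stronger inhibitor. Compound 2 `O=C(Oc1ccc(-c2cc(=S)ss2)cc1)c1cccnc1` gives 627000 nM in this assay, and compound 3 `CC(C)(Oc1ccc(Cl)cc1)C(=O)Oc1ccc(C(N)=S)cc1` gives 797000 nM. Compound 1 stands second highest of the three numbers; its nearest neighbour is compound 3, whose number lies within the scatter, and even the furthest, compound 2, lies within the scatter, so the three cannot be placed in any order.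

Compound 4 `COc1ccc(NC(=S)OCCNC(=O)C(C)(C)Oc2ccc(Cl)cc2)cc1` is the compound awaiting measurement. It differs from compound 1 in a single place: methoxy in place of methyl on an aromatic carbon. Methyl leaves and methoxy enters, on an aromatic carbon of a six-membered aromatic ring of carbon only, para to a large group.

Among the measured compounds shown here, no step between measured compounds is available, and the three measured values sit within the scatter of one another. Compound 4 is therefore expected to show a step of a 1.0-fold lower number from compound 1 to compound 4 (0.01 log units; within the scatter), not beyond the scatter. The estimate for compound 4 is 750000 nM, with a range from 400000 nM to 1400000 nM.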

Compound 4, half-maximal inhibitory concentration: 747000 nM
Compound 4: middle estimate off by 1.0-fold (0.00 log units), on the high side; the measured number falls inside the stated range.
By their numbers in this assay, from the lowest: compounds 2, 4, 1 and 3 (each within the scatter of the next).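

Among the compounds shown here, the swap from 4-methylphenyl to 4-methoxyphenyl, the only comparison here between compounds that differ in one place, gives a 1.0-fold lower number from compound 1 to compound 4 (0.01 log units; within the scatter) in this assay. At this position on the aromatic ring, para to a large group, methoxy thus reads the same as methyl within the scatter, even with the added oxygen and its hydrogen-bond acceptor. Nothing measured here speaks to why the two compounds read alike.

Only methyl and methoxy are shown at this position, so it remains open whether an amine, a carboxylic acid or a longer chain such as ethoxy would also stay within the scatter of compound 1. Going by these compounds, it is also open whether the same change would read alike on the core of compound 2 or compound 3.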